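Swapping the amide ring: expected tolerance of compound 4

The compounds below may be only part of what the source reports. "The series", "measured", "known", "first", "only" and "open" are said of these compounds alone.

Compound 2 `COc1ccc(-c2cnc(NC(=O)c3ccno3)n2C)cc1` carries a 1,2-oxazol-5-yl group on the carbonyl carbon of its amide. In a toxicity assay on THP-1 cells (Homo sapiens) for inhibition (a higher number here means that more compound is tolerated, a lower number that less compound is tolerated), compound 2 reaches only a limit, > 100000 nM, not a number. Compound 1 `COc1ccc(-c2cnc(NC(=O)c3ccc(F)cc3)n2Cc2ccccc2)cc1` also gives only a limit, > 100000 nM. Compound 3 `CCn1c(-c2ccc(OC)cc2)cnc1NC(=O)c1ccc(F)cc1` likewise stops at a limit, > 100000 nM. Going by the values given here, the one measured step, a step that the two limits leave unreadable from compound 1 to compound 3, changes the group on the chain carbon rather than the amide ring, and its size cannot be read. Compound 4 `COc1ccc(-c2cnc(NC(=O)c3cccc(Br)c3)n2C)cc1` differs from compound 2 by 3-bromophenyl in place of 1,2-oxazol-5-yl on a carbonyl carbon. Among the compounds with values here, no measured step touches this change, and because the limit of > 100000 nM in this assay, at which 3 of the 3 values shown sit, no direction can be read for it. Compound 4 is therefore expected to sit at the same limit, estimated at 100000 nM with a range from 50000 nM to 200000 nM. The expected step is a number no higher from compound 2 to compound 4 (the limit leaves the size open), none beyond the scatter.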

Compound 4, half-maximal cytotoxic concentration: > 100000 nM
Compound 4 was reported as a limit; the forecaster's own chance of this, stated with the estimate: 80%; the middle value sits exactly at the limit.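

Compound 2 and compound 4 are both reported only as limits, so no step between them can be read: the limit of > 100000 nM in this assay, at which 4 of the 4 values shown sit.

The compounds shown leave open what change, if any, would bring a measurable number in this assay.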